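The source may report more compounds than this note shows. Statements on the series, on what has been measured and on what is new or still open speak of the compounds shown alone.

Working notes on the series. In a functional assay on SW-620 cells (Homo sapiens) for inhibition (on this read-out higher numbers stand for weaker inhibition and lower numbers for stronger inhibition), compound 1 `CN1C(=O)NC2(CSC3=C2C(=O)c2ccccc2C3=O)C1=O` gives 108 nM, the low end of the two numbers shown, while compound 2 `O=C1C2=C(C(=O)c3ccccc31)C1(CS2)NC(=O)N(CCCO)C1=O` gives 119 nM in this assay; the step of a 1.1-fold higher number from compound 1 to compound 2 (0.04 log units; within the scatter) is within the scatter, so the two are treated as equivalent.

Compound 3 `NCCCN1C(=O)NC2(CSC3=C2C(=O)c2ccccc2C3=O)C1=O` differs from compound 1 by 2-aminoethyl in place of hydrogen on a saturated chain carbon bound to an amide-type nitrogen in a ring. Among the measured compounds shown here, the only measured step that bears on this is the one from compound 1 to compound 2, which put 2-hydroxyethyl in place of hydrogen at the same saturated chain carbon bound to an amide-type nitrogen in a ring and came to a 1.1-fold higher number from compound 1 to compound 2 (0.04 log units; within the scatter), nothing beyond the scatter. A chain of the same length with a hydrogen-bond donor and acceptor again is expected to behave alike in this assay, so the step of a 1.1-fold higher number from compound 1 to compound 3 (0.03 log units; within the scatter) is expected to stay within the scatter. Compound 3 is therefore estimated at 115 nM, between 55 nM and 240 nM.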

Compound 3, half-maximal inhibitory concentration: 52 nM
Beside the measured number, compound 3's estimate is 2.2-fold (0.34 log units) above it, and the stated range ends above it.
By their numbers in this assay, from the lowest: compound 3; then compounds 1 and 2 (each within the scatter of the next).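

At this position the change is not neutral: with 2-aminoethyl in place of hydrogen, the step is a 2.1-fold lower number from compound 1 to compound 3 (0.32 log units; beyond the scatter) in this assay, whereas the 2-hydroxyethyl change stayed within the scatter. Amino in place of hydroxy at the chain end gives a 2.3-fold lower number from compound 2 to compound 3 (0.36 log units; beyond the scatter), so the end group, and not the presence of the chain alone, separates compound 3 from compound 2, though both steps are modest. No evidence is available to account for this difference.

The compounds shown leave open whether the lower number is tied to a primary amine or would also appear with a dimethylamino group or a carboxylic acid at the chain end. From the compounds shown here alone, whether a longer chain carrying the amino group would keep it also remains open.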